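Thiophene attachment point on the methylamino side chain

The compounds below may be only part of what the source reports. "The series", "measured", "known", "first", "only" and "open" are said of these compounds alone.

Compound 2 `CN(Cc1cccs1)C1CCN(CCCc2c[nH]c3ccc(-n4cnnc4)cc23)CC1` gives 81% in a functional assay on CHO cells for activation of 5-hydroxytryptamine receptor 1D (Homo sapiens), read by GTPgammaS binding; a lower number here means a smaller maximal response, a higher number a larger maximal response. Within the data shown here, compound 1 `OC[C@H](NC1CCN(CCCc2c[nH]c3ccc(-n4ccnc4)cc23)CC1)c1ccccc1` gives 74% in this assay; the two values lie within the scatter of each other, so the numbers so far do not separate compound 2 from compound 1. Compound 3 `CN(Cc1ccsc1)C1CCN(CCCc2c[nH]c3ccc(-n4cnnc4)cc23)CC1` is not yet measured and differs from compound 2 by thiophen-3-yl in place of thiophen-2-yl on a saturated chain carbon bound to an amine nitrogen. Among the measured compounds shown here, no step between measured compounds covers this change; the step from compound 2 to compound 3 is expected to stay within the scatter, with no direction favoured, a number 1 percentage points lower from compound 2 to compound 3 (within the scatter). For compound 3 the estimate in this assay is 80%, between 65% and 95%.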

Compound 3, largest response reached (reported as efficacy), in percent of the reference or control that the assay uses: 93%
Beside the measured number, compound 3's estimate is 13 percentage points below it, within the range that was stated.
By their numbers in this assay, from the lowest: compounds 1 and 2 (each within the scatter of the next); then compound 3.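

In this assay the attachment point on the thiophene counts: thiophen-3-yl in place of thiophen-2-yl gives a number 12 percentage points higher from compound 2 to compound 3 (beyond the scatter) with the same atoms joined differently. Among these compounds, this is the first single-place change with a readable step, and it shows that this position responds to a change of attachment alone. Nothing measured on these compounds accounts for the step.

On these data alone, whether the step carries over to the core of compound 1 remains open. Also open, as far as these compounds go, is whether furan-3-yl, or a longer chain to the amine nitrogen, would hold the response of compound 3.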